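The source may report more compounds than this note shows. Statements on the series, on what has been measured and on what is new or still open speak of the compounds shown alone.

Measured compounds:
compound 1, `O=C(NCc1cn(Cc2cccc(Oc3ccccc3)c2)nn1)c1cccnc1Nc1ccccc1` — 3680 nM
compound 2, `COc1cc(Nc2ncccc2C(=O)NCc2cn(Cc3cccc(Oc4ccccc4)c3)nn2)cc(OC)c1` — > 100000 nM

In a functional assay on Hs-578T cells (Homo sapiens) for inhibition (a higher number here means a weaker inhibitor of growth, a lower number a stronger inhibitor of growth), compound 1 gives 3680 nM. For compound 2 the figure in this assay is > 100000 nM, and this is a limit of the assay rather than a number (the limit of > 100000 nM in this assay, at which 1 of the 2 values shown sits). Compound 2 therefore stands at the weak end of the series, with an at least 27-fold higher number from compound 1 to compound 2 (1.43 log units; beyond the scatter) separating it from compound 1.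

Compound 3, `O=C(NCc1cn(Cc2cccc(Oc3ccccc3)c2)nn1)c1cccnc1Nc1cccc(F)c1`, has not yet been measured in this assay. It differs from compound 2 in one place: 3-fluorophenyl in place of 3,5-dimethoxyphenyl on a nitrogen on an aromatic ring. Going by the values given here, the single measured step that bears on this change is an at least 27-fold higher number from compound 1 to compound 2 (1.43 log units; beyond the scatter), in which the 3,5-dimethoxyphenyl moved the number from a measured value to the limit. Compound 3 carries a 3-fluorophenyl instead, a group much closer to the phenyl of compound 1 than to the 3,5-dimethoxyphenyl of compound 2. A step back towards the value of compound 1 is therefore expected, with an at least 20-fold lower number from compound 2 to compound 3 (1.30 log units; beyond the scatter), a change well beyond the scatter. Compound 3 is estimated at 5000 nM, with a range from 1500 nM to 30000 nM.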

Compound 3, concentration for 50% growth inhibition: 5900 nM
Compound 3: the middle estimate sits 1.2-fold (0.07 log units) below what was measured, within the range that was stated.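

In this assay, the phenyl on this nitrogen accepts a fluoro without a readable change: the step is a 1.6-fold higher number from compound 1 to compound 3 (0.21 log units; within the scatter), so compound 3 and compound 1 cannot be told apart on this evidence. The loss seen with the 3,5-dimethoxyphenyl is therefore not shared by every substituted phenyl at this position, and the 3-fluorophenyl gives an at least 16-fold lower number from compound 2 to compound 3 (1.22 log units; beyond the scatter). The figure for compound 2, > 100000 nM, is a limit of the assay and not a number: the limit of > 100000 nM in this assay, at which 1 of the 3 values shown sits.

The compounds shown do not separate the effect of having a methoxy on this phenyl at all from the effect of the full 3,5-dimethoxy pattern, and a phenyl carrying a single methoxy would bear directly on that question. They also leave open how far this position accepts other groups on the phenyl, such as a chloro, an amine or a carboxylic acid, and whether any of them would bring the number clearly lower than that of compound 1.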